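Chain length of the acid on the aryl amine series

The source may hold more compounds than are shown below. What is called first, only, known or untested is meant among the compounds shown, and "the series" means these compounds.

Compound 1 `Cc1nc(-c2ccc(C(F)(F)F)cc2)sc1CNc1ccc(CCC(=O)O)cc1` carries a 2-carboxyethyl group and in a functional assay on CHO cells for agonist activity at Free fatty acid receptor 1 (Homo sapiens) (on this read-out lower numbers stand for an effect already at smaller amounts and higher numbers for an effect only at larger amounts of compound), compound 1 gives 67.6 nM. Compound 2 `Cc1nc(-c2ccc(C(F)(F)F)cc2)sc1CNc1ccc(C(=O)O)cc1` bears the carboxy group directly on the aromatic carbon and gives < 10000 nM, which is a limit of the assay and not a number. Compound 3 `Cc1nc(-c2ccc(C(F)(F)F)cc2)sc1CNc1ccc(CC(=O)O)cc1` carries a carboxymethyl group and gives < 10000 nM, again a limit and not a number. The steps a step that the limit leaves unreadable from compound 1 to compound 2 and a step that the limit leaves unreadable from compound 1 to compound 3 cannot be sized, nor can a step that the two limits leave unreadable from compound 2 to compound 3, because the limit of < 10000 nM in this assay, at which 2 of the 3 values shown sit, hides where those two compounds stand.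

Compound 4 `Cc1nc(-c2ccc(C(F)(F)F)cc2)sc1CNc1ccc(CCCC(=O)O)cc1` is the next homologue. Relative to compound 3 the change is 2-carboxyethyl in place of carboxy on a saturated chain carbon bound to an aromatic carbon; the same difference, cut one bond further out, reads carboxymethyl to 3-carboxypropyl. Among the compounds with values here, no measured step tells directly how a 3-carboxypropyl group behaves. The shorter acids of compound 2 and compound 3 each stand at a limit of the assay. Within the data shown here, the only anchor is therefore compound 1 with its 2-carboxyethyl group and 67.6 nM. The expectation is that compound 4 lands weaker than compound 1 but clear of the limit, so the step that the limit leaves unreadable from compound 3 to compound 4 is estimated to run toward smaller concentrations. Compound 4 is expected near 400 nM, within roughly 80 nM to 3000 nM.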

Compound 4, half-maximal effective concentration: < 10000 nM
Compound 4 gave a limit, no number; the forecaster's own chance of this, stated with the estimate: 15%; the middle value lies beyond the limit too.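

No new step can be read for compound 4 against compound 1, compound 2 or compound 3, because each comparison meets a limit and not a number: the limit of < 10000 nM in this assay, at which 3 of the 4 values shown sit.

The compounds shown leave open where compound 2, compound 3 and compound 4 truly stand in this assay, and so how far each lies from compound 1.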